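The source may report more compounds than this note shows. Statements on the series, on what has been measured and on what is new or still open speak of the compounds shown alone.

Measured compounds:
compound 1 `CCN1CCN(c2cc(C)c3cc(NC(=O)c4ccc5ccccc5n4)ccc3n2)CC1`, 7060 nM
compound 2 `CCN1CCN(c2cc(C)c3cc(NC(=O)c4ccc(F)cc4)ccc3n2)CC1`, 4030 nM

In a functional assay on MCF7 cells (Homo sapiens) for antiproliferative activity, read by MTT assay, with a stated time of 72 h (on this read-out higher numbers stand for weaker inhibition and lower numbers for stronger inhibition), compound 2 gives 4030 nM, the lowest of the two numbers shown, although the gap to compound 1 is within the scatter. Compound 3 `CCN1CCN(c2cc(C)c3cc(NC(=O)c4cccc(C)c4)ccc3n2)CC1` is not yet measured. It differs from compound 2 in one place: 3-methylphenyl in place of 4-fluorophenyl on a carbonyl carbon.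

For the measured compounds named here, the one measured step that bears on this place is the exchange of the aryl group on the carbonyl carbon, a 1.8-fold lower number from compound 1 to compound 2 (0.24 log units; within the scatter), which lay within the scatter. On that basis no step beyond the scatter is expected from compound 2 to compound 3; the data give no further guidance for this change. For compound 3 the estimate in this assay is 4500 nM, with a range from 1800 nM to 11000 nM. Going by the values given here, the expected step of a 1.1-fold higher number from compound 2 to compound 3 (0.05 log units; within the scatter) thus lies within the scatter, with the range left wide because only one comparable step is known.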

Compound 3, half-maximal inhibitory concentration: 7800 nM
Compound 3: the middle estimate sits 1.7-fold (0.24 log units) below what was measured; the range from low to high includes it.
By their numbers in this assay, from the lowest: compounds 2, 1 and 3 (each within the scatter of the next).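

In this assay, 3-methylphenyl in place of 4-fluorophenyl on the carbonyl carbon gives a 1.9-fold higher number from compound 2 to compound 3 (0.29 log units; within the scatter), and 3-methylphenyl in place of quinolin-2-yl gives a 1.1-fold higher number from compound 1 to compound 3 (0.04 log units; within the scatter). All three aryl groups at this place now read alike within the scatter, so neither the 3-methylphenyl exchange nor either earlier group has yet produced a step beyond it. Nothing available explains this reading.

From the compounds shown here alone, whether a different kind of group on this carbonyl carbon, such as an aminophenyl, a carboxylic acid or a longer alkyl chain, would move the number beyond the scatter remains open. Also open, going by these compounds, is whether 4-methylphenyl or 3-fluorophenyl would read like 3-methylphenyl and 4-fluorophenyl, which would separate the choice of group from where it sits on the phenyl ring.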